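A few compounds are considered here, and "the series" means these few. Any claim that something is new, unique, unknown or untested is made for them only; others in the source may bear on it.

Of the compounds shown here, three built on the same core have been tested so far. Compound 1 `COC(=O)C1=C(N)Oc2c(OC)cc(Br)cc2C1CC(=O)c1ccc(Cl)cc1`, compound 2 `COC(=O)C1=C(N)Oc2c(OC)cc(Br)cc2C1CC(=O)c1ccc(Br)cc1` and compound 3 `COC(=O)C1=C(N)Oc2ccc(Br)cc2C1CC(=O)c1ccc(Br)cc1` differ only in the groups attached to their aromatic rings. In a functional assay on MCF7 cells (Homo sapiens) for antiproliferative activity, read by sulforhodamine B assay, with a stated time of 72 h, tested at 30 uM (on this read-out higher numbers stand for a weaker effect at the one concentration tested and lower numbers for a stronger effect), compound 1 gives 33.8%, compound 2 gives 31.9% and compound 3 gives 34.8%. Swapping bromo in place of chloro on an aromatic carbon gives a number 1.9 percentage points lower from compound 1 to compound 2 (within the scatter), and hydrogen in place of methoxy on an aromatic carbon gives a number 2.9 percentage points higher from compound 2 to compound 3 (within the scatter). Compound 2 therefore carries the smallest number of the three, but both gaps to it are within the scatter, so the three compounds cannot be told apart on this read-out.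

Compound 4 `COc1cc(Br)cc2c1OC(N)=C(C#N)C2CC(=O)c1ccc(Br)cc1` changes something different: cyano in place of methoxycarbonyl on a double-bonded ring carbon. Among the measured compounds shown here, this touches the non-aromatic ring of the core rather than an aromatic ring, and neither measured step exchanges a group at that position, so no step of the same kind is known. The two measured steps only show that small changes elsewhere left the read-out unchanged within the scatter. The expected step of a number 3.1 percentage points higher from compound 2 to compound 4 (within the scatter) is accordingly small, with no clear direction, so compound 4 is estimated at 35% in this assay, with a range from 20% to 52%.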

Compound 4, a percentage reported as activity, at one concentration (the size of the read-out at that concentration, not a potency): 33.1%
Beside the measured number, compound 4's estimate is 1.9 percentage points above it, and the stated range covers the measured number.
By their numbers in this assay, from the lowest: compounds 2, 4, 1 and 3 (each within the scatter of the next).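

In this assay, the exchange of methoxycarbonyl for cyano gives a number 1.2 percentage points higher from compound 2 to compound 4 (within the scatter), the first step read at this double-bonded ring carbon of the non-aromatic ring. The change is sizeable on paper: a group of 4 heavy atoms with 2 hydrogen-bond acceptors gives way to one of 2 heavy atoms with 1 hydrogen-bond acceptor, yet this pair cannot be told apart on this read-out, so for this one pair the exact group at this carbon makes no visible difference. Nothing measured alongside these compounds speaks to why the two groups read alike.

The compounds shown carry only methoxycarbonyl and cyano at this carbon, so they leave open how a carboxylic acid, an amide or an ester with a longer chain would read there. Compound 2 and compound 4 are also compared at one concentration only, which leaves open whether they would stay together at lower concentrations, where a difference between them might still appear.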